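Dropping two methoxy groups from compound 3

This account rests on a few compounds, and the source may have more. Where it says the series, first, only, none or still open, it means among the compounds named here.

Compound 3 `COc1cc(-c2cc(/C=C/C(=O)c3ccccc3)nc3cc(-c4ccccc4)nn23)cc(OC)c1OC` gives 34300 nM in a functional assay on DU-145 cells (Homo sapiens) for antiproliferative activity, read by MTT assay, with a stated time of 24 h (on this read-out higher numbers stand for weaker inhibition and lower numbers for stronger inhibition), the highest of the three numbers measured. Compound 1 `COc1ccc(C(=O)/C=C/c2cc(-c3cc(OC)c(OC)c(OC)c3)n3nc(-c4ccccc4)cc3n2)cc1` gives 25200 nM in this assay, and compound 2 `COc1ccc(-c2cc(/C=C/C(=O)c3ccc(OC)c(OC)c3)nc3cc(-c4ccccc4)nn23)cc1` gives 16400 nM in this assay. Going by the values given here, the step of a 1.4-fold higher number from compound 1 to compound 3 (0.13 log units; within the scatter) is the only single change measured, and it is small. Compound 4 `COc1ccc(-c2cc(/C=C/C(=O)c3ccccc3)nc3cc(-c4ccccc4)nn23)cc1` differs from compound 3 by 4-methoxyphenyl in place of 3,4,5-trimethoxyphenyl on an aromatic carbon. Among the compounds with values here, no measured step tests exactly this change; compound 2 also carries a 4-methoxyphenyl group but differs in a second place as well, so its value is only a weak hint. The change is therefore expected to move this assay little, with a step of a 1.2-fold lower number from compound 3 to compound 4 (0.09 log units; within the scatter) expected. Compound 4 is estimated at 28000 nM, within a range of 12000 nM to 65000 nM.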

Compound 4, half-maximal inhibitory concentration: 13700 nM
Compound 4: middle estimate off by 2.0-fold (0.31 log units), on the high side; the range from low to high includes it.
By their numbers in this assay, from the lowest: compounds 4, 2, 1 and 3 (each within the scatter of the next, the first and the last beyond it).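

In this assay, going by these compounds alone, replacing 3,4,5-trimethoxyphenyl with 4-methoxyphenyl on the aromatic carbon next to the ring nitrogen gives a 2.5-fold lower number from compound 3 to compound 4 (0.40 log units; beyond the scatter), the first single change here to go beyond the scatter. On the carbonyl carbon, phenyl in place of 3,4-dimethoxyphenyl gives a 1.2-fold lower number from compound 2 to compound 4 (0.08 log units; within the scatter), so with 4-methoxyphenyl in place this second change has no clear effect. Nothing available explains either result. Still open, as far as these compounds go, is how this position responds to a plain phenyl or to a phenyl bearing an amine or a carboxylic acid.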